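The source may hold more compounds than are shown below. What is called first, only, known or untested is meant among the compounds shown, and "the series" means these compounds.

Working notes on the series.

Compound 1 `Cc1ccc(S(=O)(=O)NC(=O)/C=C/c2ccc(Cl)cc2)cc1` and compound 2 `Cc1ccc(S(=O)(=O)NC(=O)/C=C/c2ccc(Br)cc2)cc1` share one core; compound 3 `COc1ccc(/C=C/C(=O)NS(=O)(=O)c2ccc(Cl)cc2)cc1` and compound 4 `COc1ccc(/C=C/C(=O)NS(=O)(=O)c2ccc(Br)cc2)cc1` share another. The difference between the two cores is not broken down here.

In a functional assay on B16-F10 cells (Mus musculus) for antiproliferative activity, read by ELISA and MTT assay, with a stated time of 48 h (on this read-out lower numbers stand for stronger inhibition and higher numbers for weaker inhibition), compound 1 gives 4.6 ug/mL. Compound 2 gives 12.1 ug/mL in this assay. The change between them is bromo in place of chloro on an aromatic carbon, and the step it made is a 2.6-fold higher number from compound 1 to compound 2 (0.42 log units; beyond the scatter).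

Compound 3 gives 5.3 ug/mL in this assay. Its number and that of compound 1 lie within the scatter of each other, so no order is read between them; against compound 2 its number is the lower, beyond the scatter.

Compound 4 is not yet measured. It differs from compound 3 by bromo in place of chloro on an aromatic carbon, the same change that was made from compound 1 to compound 2, at a place described in the same words in both cases. With a single earlier instance of the change, the expectation rests on that one step: compound 4 is expected to sit at a higher number than compound 3, with a step estimated as a 2.3-fold higher number from compound 3 to compound 4 (0.35 log units; beyond the scatter), because the earlier step was a 2.6-fold higher number from compound 1 to compound 2 (0.42 log units; beyond the scatter). For compound 4 in this assay the estimate is 12 ug/mL, with an expected range from 5 ug/mL to 28 ug/mL.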

Compound 4, half-maximal inhibitory concentration: 5.8 ug/mL
Compound 4: middle estimate off by 2.1-fold (0.32 log units), on the high side; the range from low to high includes it.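

In this assay, bromo in place of chloro on the core shared with the methoxy compounds gives a 1.1-fold higher number from compound 3 to compound 4 (0.04 log units; within the scatter), and set beside the earlier instance of the same change it reads: the same change on two cores in this assay, a 2.6-fold higher number (0.42 log units; beyond the scatter) from compound 1 to compound 2 and a 1.1-fold higher number (0.04 log units; within the scatter) from compound 3 to compound 4, 2.4-fold (0.38 log units) apart, within the scatter of two such steps. The step is beyond the scatter on one core and within it on the other, yet the gap between the two steps is itself within the scatter, so these compounds give no ground for saying that the change behaves differently on the two cores. Nor do they show that it behaves the same: each core offers a single pair, so the data can neither separate a real dependence on the core from ordinary assay scatter nor say how the change would behave on any third core.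

Open, on these data alone, is how other groups at the same place on the aromatic ring, para to a large group, would stand against chloro and bromo on either core, for example fluoro, iodo, a nitrile or an amine. Also open, as far as these compounds go, is whether the chloro and bromo steps would keep their size if the methyl on the core of compound 1 or the methoxy on the core of compound 3 gave way to another group, such as a carboxylic acid or a longer chain.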